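This account rests on a few compounds, and the source may have more. Where it says the series, first, only, none or still open, it means among the compounds named here.

Among the three compounds whose numbers are known, compound 3 `CC1(C)C[C@H](Nc2cc(NCc3cnccc3C(F)(F)F)ncc2C#N)CC[C@@H]1O` gives the lowest: in an assay on isolated protein for inhibition of protein kinase C theta type (Homo sapiens), read by TR-FRET, with a stated time of 2 h (a lower number here means a stronger inhibitor, a higher number a weaker inhibitor), compound 3 gives 7 nM. Compound 1 `N#Cc1cnc(NCc2cnccc2C(F)(F)F)cc1N[C@H]1C[C@@H](O)C1` gives 500 nM in this assay, and compound 2 `N#Cc1cnc(NCc2cnccc2C(F)(F)F)cc1NCCC1CCOCC1` gives 1200 nM. The group attached to the nitrogen on the aromatic ring is what sets these apart: going from compound 1 to compound 2 changed the number by a 2.4-fold higher number from compound 1 to compound 2 (0.38 log units; beyond the scatter), from compound 1 to compound 3 by a 71-fold lower number from compound 1 to compound 3 (1.85 log units; beyond the scatter), and from compound 2 to compound 3 by a 170-fold lower number from compound 2 to compound 3 (2.23 log units; beyond the scatter).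

Compound 4 `CC1(C)[C@H](Nc2cc(NCc3cnccc3C(F)(F)F)ncc2C#N)C[C@H]1C(N)=O` is made from compound 3 by the change (3-carbamoyl-2,2-dimethylcyclobutyl in place of 4-hydroxy-3,3-dimethylcyclohexyl on a nitrogen on an aromatic ring). Compound 1 is the nearest guide, since it also carries a four-membered ring with a hydrogen-bond donor at the same place, and the path from compound 1 to compound 3 was a 71-fold lower number from compound 1 to compound 3 (1.85 log units; beyond the scatter). Compound 4 keeps the two methyl groups of compound 3, however, and carries a carbamoyl rather than a hydroxy group, so neither measured step covers the change exactly. The expected step from compound 3 to compound 4 is an 8.6-fold higher number from compound 3 to compound 4 (0.93 log units; beyond the scatter), a rise in the number that falls short of returning to compound 1. Compound 4 is therefore estimated at 60 nM, between 10 nM and 400 nM.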

Compound 4, half-maximal inhibitory concentration: 140 nM
Beside the measured number, compound 4's estimate is 2.3-fold (0.37 log units) below it, and the stated range covers the measured number.
By their numbers in this assay, from the lowest: compound 3; then compound 4; then compound 1; then compound 2.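

The 3-carbamoyl-2,2-dimethylcyclobutyl group has the same counts of heavy atoms, hydrogen-bond donors and hydrogen-bond acceptors as the 4-hydroxy-3,3-dimethylcyclohexyl group it replaces, and it keeps the two methyl groups, yet the number still rises (a 20-fold higher number from compound 3 to compound 4 (1.30 log units; beyond the scatter)), so these shared features are not enough to match compound 3. A four-membered ring on this nitrogen does not have to give a weak number, however, since the new group improves on the 3-hydroxycyclobutyl group (a 3.6-fold lower number from compound 1 to compound 4 (0.55 log units; beyond the scatter)) and on the 2-(oxan-4-yl)ethyl group (an 8.6-fold lower number from compound 2 to compound 4 (0.93 log units; beyond the scatter)). No measurement offered here explains any of these differences.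

Going by these compounds, the change from compound 3 to compound 4 alters the ring size and swaps hydroxy for carbamoyl in one move, so the share of each in the rise stays open. A 4-carbamoyl-3,3-dimethylcyclohexyl group or a 3-hydroxy-2,2-dimethylcyclobutyl group on the same nitrogen would separate the two, with all else in the core unchanged.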